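From cyano to carboxy on a shared core

A few compounds are considered here, and "the series" means these few. Any claim that something is new, unique, unknown or untested is made for them only; others in the source may bear on it.

Measured in a functional assay on LoVo cells (Homo sapiens) for cytotoxicity, read by colorimetric assay and MTT assay; on this read-out higher numbers stand for weaker inhibition and lower numbers for stronger inhibition:
- compound 1 `COc1ccc(-c2cc3cccc(OC)c3nc2O)cc1`: 10000 nM
- compound 2 `CCN(CC)C(=O)Cn1c(=O)c(-c2ccc(OC)cc2)cc2c(OC)cc(OC)cc21`: 10000 nM
- compound 3 `COc1ccc(-c2cc3c(OC)cc(OC)cc3n(CC#N)c2=O)cc1`: 10000 nM

All three compounds stand level on these numbers, so compound 3 is neither ahead of nor behind the other two. The next structure, compound 4 `COc1ccc(-c2cc3c(OC)cc(OC)cc3n(CC(=O)O)c2=O)cc1`, makes one change to compound 3: carboxy in place of cyano on a saturated chain carbon bound to an aromatic nitrogen. In words, carboxy takes the place of cyano on a saturated chain carbon bound to an aromatic nitrogen. Within the data shown here, only one measured step touches this place: no change at the digits printed from compound 2 to compound 3 (within the scatter). Among the measured compounds shown here, no measured step involves carboxy itself, so this evidence is thin. Expected here is no change at the digits printed from compound 3 to compound 4 (within the scatter), meaning no step beyond the scatter in this assay. For compound 4, the estimated value is 10000 nM, with an expected range of 6000 nM to 20000 nM.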

Compound 4, half-maximal inhibitory concentration: 10000 nM
The estimate for compound 4 equals the measured number at the digits printed; measured number inside the range.
By their numbers in this assay, from the lowest: compounds 1, 2, 3 and 4 (each within the scatter of the next).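

In this assay, carboxy in place of cyano gives a flat result (no change at the digits printed from compound 3 to compound 4 (within the scatter)), and hydroxy in place of diethylamino on a carbonyl carbon does the same (no change at the digits printed from compound 2 to compound 4 (within the scatter)). Among these compounds, on this saturated chain carbon bound to an aromatic nitrogen, the carboxy group now reads level with both the cyano group and the diethylamide, adding a free acid to the comparison for the first time. No measurement shown here explains this flat result.

Still open, as far as these compounds go, is whether an amine or a longer chain ending in carboxy at this place would read any differently.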